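A few compounds are considered here, and "the series" means these few. Any claim that something is new, unique, unknown or untested is made for them only; others in the source may bear on it.

In an ADME assay (Canis lupus familiaris, strain Beagle) for pharmacokinetics (on this read-out lower numbers stand for narrower distribution and higher numbers for wider distribution into tissues), compound 1 (`CCn1c(-c2cnc(C)nc2)nc2c(N[C@H]3CCN(C(=O)[C@H]4C[C@@H](OC)C4)C3)ncnc21`) gives 2 L/kg while compound 2 (`CCC(=O)N1CC[C@H](Oc2ncnc3c2nc(-c2cnc(C)nc2)n3CC)C1`) gives 2.7 L/kg and compound 3 (`CCn1c(-c2cnc(C)nc2)nc2c(O[C@H]3CCN(C(=O)N4CC(OC)C4)C3)ncnc21`) gives 2.3 L/kg on the same scale, so compound 1 stands within the scatter of both. Compound 4 (`CCn1c(-c2cnc(C)nc2)nc2c(N[C@H]3CCN(C(=O)C4CC4)C3)ncnc21`) has not yet been measured and carries cyclopropyl in place of 3-methoxycyclobutyl on a carbonyl carbon. Going by the values given here, the one measured step that changes the group on a carbonyl carbon puts 3-methoxyazetidin-1-yl in place of ethyl (a 1.2-fold lower number from compound 2 to compound 3 (0.07 log units; within the scatter)) and stays within the scatter. No step beyond the scatter is therefore expected in this assay for compound 4, with at most a slight lean toward compound 2 (2.7 L/kg) which, like compound 4, has no methoxy group. The expected change is small (a 1.2-fold higher number from compound 1 to compound 4 (0.06 log units; within the scatter)) and remains an estimate within the scatter. Compound 4 is estimated at 2.3 L/kg with 1.4 L/kg to 3.6 L/kg as the expected range.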

Compound 4, volume of distribution: 1.8 L/kg
Compound 4: middle estimate off by 1.3-fold (0.11 log units), on the high side, within the range that was stated.
By their numbers in this assay, from the lowest: compounds 4, 1, 3 and 2 (each within the scatter of the next).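

In this assay, the whole 3-methoxycyclobutyl on the carbonyl carbon gives way to cyclopropyl, a smaller group without the methoxy oxygen or the two defined stereocentres, and the result is a 1.1-fold lower number from compound 1 to compound 4 (0.05 log units; within the scatter) as the read-out. Going by these compounds alone, this is a second change at a carbonyl carbon to stay within the scatter, alongside the earlier 1.2-fold lower number from compound 2 to compound 3 (0.07 log units; within the scatter) on a different compound pair, and it is the first such change made directly on compound 1. No evidence is at hand to account for this result.

The compounds shown leave open whether an amine, a carboxylic acid or a longer alkyl chain on this carbonyl carbon would bring a step beyond the scatter. They also leave open whether cyclopropyl would give a similar step on the frameworks of compound 2 and compound 3.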